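Allyl carbamate on a phenyl selenocyanate core

The source may hold more compounds than are shown below. What is called first, only, known or untested is meant among the compounds shown, and "the series" means these compounds.

Compound 1 `CCCCOC(=O)Nc1ccc([Se]C#N)cc1` gives 6600 nM in a functional assay on MCF7 cells (Homo sapiens) for cytotoxicity, read by MTT assay, with a stated time of 72 h; a higher number here means a weaker inhibitor of growth, a lower number a stronger inhibitor of growth.
Compound 2 `CC(C)COC(=O)Nc1ccc([Se]C#N)cc1` gives 18100 nM in this assay.

Compound 2 stands highest of the two measured numbers in this assay. For the measured compounds named here, the single measured step is a 2.7-fold higher number from compound 1 to compound 2 (0.44 log units; beyond the scatter), in which isopropyl took the place of propyl and the number rose. Compound 3 `C=CCOC(=O)Nc1ccc([Se]C#N)cc1` differs from compound 2 by vinyl in place of isopropyl on a saturated chain carbon bound to an oxygen next to a carbonyl group. Going by the values given here, that one step bears on the change in so far as the isopropyl group that raised the number is now removed, though no measured step covers a vinyl group or the double bond it brings, so the direction rests on a single comparison. A modest downward step in this assay is therefore expected, not confidently beyond the scatter. Compound 3 is estimated at 8500 nM, with a range from 3000 nM to 25000 nM. The expected step is a 2.1-fold lower number from compound 2 to compound 3 (0.33 log units; beyond the scatter).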

Compound 3, concentration for 50% growth inhibition: 15000 nM
Estimate against measurement, compound 3: 1.8-fold (0.25 log units) below; measured number inside the range.
By their numbers in this assay, from the lowest: compound 1; then compounds 3 and 2 (each within the scatter of the next).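

With vinyl in place of isopropyl at this saturated chain carbon, the two compounds cannot be told apart in this assay (a 1.2-fold lower number from compound 2 to compound 3 (0.08 log units; within the scatter)), so isobutyl and allyl read alike here. The step with vinyl in place of propyl lies beyond the scatter (a 2.3-fold higher number from compound 1 to compound 3 (0.36 log units; beyond the scatter)), which leaves compound 1 apart from the other two and shows that removing the isopropyl does not by itself return the number to that of compound 1. Nothing available explains these numbers.

The shown compounds leave open whether a longer straight chain, such as hexyl, would carry the number lower than compound 1 does. They also leave open how a benzyl group or a chain ending in an amine would read at this place.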